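The compounds below may be only part of what the source reports. "The series", "measured", "known", "first", "only" and "open" are said of these compounds alone.

Of the compounds shown here, three have been read so far in a physicochemical assay for solubility; a higher number here means a more soluble compound, a lower number a less soluble compound. Among the measured compounds shown here, compound 2 `CNC(=O)c1cccn(Cc2ccccc2)c1=O` gives 78 ug/mL, the only actual number in the set. Compound 3 `CNC(=O)c1ccc(=O)n(Cc2ccccc2)c1` reports >= 108 ug/mL, which is a limit of the assay. Compound 1 `CNC(=O)c1cc(C(=O)NCCCC2CNCCO2)cn(Cc2ccccc2)c1=O` reports >= 194 ug/mL, also a limit. Compound 4 `CNC(=O)c1cc(C(N)=O)cn(Cc2ccccc2)c1=O` is compound 2 with one change, carbamoyl in place of hydrogen on an aromatic carbon. For the measured compounds named here, no measured pair isolates this change, and the two limits fix no size for it. The expected outcome in this assay is therefore no step beyond the scatter, with neither direction favoured. The estimated step of a 1.0-fold lower number from compound 2 to compound 4 (0.02 log units; within the scatter) is correspondingly small. Compound 4 is expected at 75 ug/mL, within an estimated range of 25 ug/mL to 135 ug/mL.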

Compound 4, solubility: 71 ug/mL
The estimate for compound 4 lay 1.1-fold (0.02 log units) above the measured number, and the stated range covers the measured number.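

In this assay, carbamoyl in place of hydrogen on the aromatic carbon two atoms from the ring nitrogen gives a 1.1-fold lower number from compound 2 to compound 4 (0.04 log units; within the scatter), so at this position the group brings no step beyond the scatter. Hydrogen in place of 3-(morpholin-2-yl)propyl on the amide-type nitrogen gives an at least 2.7-fold lower number from compound 1 to compound 4 (0.43 log units; beyond the scatter). The value of compound 1 is a limit of the assay, so this step is a bound and not a size: the limit of >= 194 ug/mL in this assay, at which 1 of the 4 values shown sits.

Still open, on these data alone, is how a carboxylic acid or an amine at the same position would read. Also open, as far as these compounds go, is whether the morpholine ring or the propyl chain carries the step, which a plain propyl group on that nitrogen would separate.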